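This account rests on a few compounds, and the source may have more. Where it says the series, first, only, none or still open, it means among the compounds named here.

Measured compounds:

compound 1, `O=C(CCCCC1CCSS1)NCc1cn(CCCOc2ccc3cc(-c4ccc(Br)cc4)c(=O)oc3c2)nn1`, 69.1%
compound 2, `O=C(CCCCC1CCSS1)NCc1cn(CCCOc2ccc3cc(-c4ccc(Cl)cc4)c(=O)oc3c2)nn1`, 75.6%
compound 3, `O=C(CCCCC1CCSS1)NCc1cn(CCCCOc2ccc3cc(-c4ccc(Br)cc4)c(=O)oc3c2)nn1`, 45%

All three were tested in a functional assay on PC-12 cells (Rattus norvegicus) for cytotoxicity, read by MTT assay, with stated times of 3 h and 2 h, tested at 20 uM; on this read-out lower numbers stand for a weaker effect and higher numbers for a stronger effect at the one concentration tested. Compound 1 and compound 2 share a core and differ in one place only: chloro in place of bromo on an aromatic carbon. On this change the read-out moved by a number 6.5 percentage points higher from compound 1 to compound 2 (within the scatter), so within this pair the two numbers cannot be told apart.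

Compound 3 carries the same bromo substituent as compound 1 but on a different core; how the two cores differ is not broken down here. In this assay compound 3 gives 45%, the lowest of the three numbers, and its distance to compound 1 and to compound 2 lies beyond the scatter.

Compound 4, `O=C(CCCCC1CCSS1)NCc1cn(CCCCOc2ccc3cc(-c4ccc(Cl)cc4)c(=O)oc3c2)nn1`, has not been measured. It relates to compound 3 as compound 2 relates to compound 1: chloro in place of bromo on an aromatic carbon. The place lines of both changes read the same word for word, so this is the same change on the other core.

For compound 4 the step is expected to be small, a number 5 percentage points higher from compound 3 to compound 4 (within the scatter), because the same change from compound 1 to compound 2 gave only a number 6.5 percentage points higher from compound 1 to compound 2 (within the scatter). Compound 4 is therefore expected to come out at 50% in this assay, with a range from 36% to 64%, starting from compound 3 at 45%. Whether the same small step holds on this second core rests on a single measured pair.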

Compound 4, a percentage reported as activity, at one concentration (the size of the read-out at that concentration, not a potency): 68.4%
Beside the measured number, compound 4's estimate is 18.4 percentage points below it; measured number outside the range, above it.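

Read in this assay the exchange of 4-bromophenyl for 4-chlorophenyl gives a number 23.4 percentage points higher from compound 3 to compound 4 (beyond the scatter) on the core of compound 3, so on this core the change is a real step and not a shift lost in the scatter. Set beside the earlier pair, the change does not carry over at one size from one core to the other: the same change on two cores in this assay, a number 6.5 percentage points higher (within the scatter) from compound 1 to compound 2 and a number 23.4 percentage points higher (beyond the scatter) from compound 3 to compound 4, 16.9 percentage points apart, beyond the scatter of two such steps. This shows that a step read on one core was a poor guide to the size of the same change on the other, but it rests on a single pair per core, gives no reason for the gap, and says nothing about how the change would behave on any further core.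

Open, going by these compounds, is whether a fluoro or a methoxy group on the same aromatic carbon would follow compound 2 or compound 4, which would show whether the gap belongs to the bromo and chloro pair alone. Also open, on these data alone, is how the exchange reads on a core with a longer chain, and whether a third core would side with the small step, the large step or neither.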